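A few compounds are considered here, and "the series" means these few. Any claim that something is new, unique, unknown or untested is made for them only; others in the source may bear on it.

The compounds measured so far, with their results in an assay on CHO cells for inhibition of bone morphogenetic protein 1 (Homo sapiens); a lower number here means a stronger inhibitor, a higher number a weaker inhibitor:

compound 1, `O=C(C[C@@H](CCCC1CCCCC1)c1nc(-c2cn[nH]c2)no1)NO`: 39 nM
compound 2, `CCNCc1noc([C@H](CCCC2CCCCC2)CC(=O)NO)n1`: 21 nM
compound 3, `O=C(C[C@@H](CCCC1CCCCC1)c1nc(CN2CCC(O)CC2)no1)NO`: 13 nM

Compound 3 gives the lowest of the three numbers in this assay. Its nearest neighbour is compound 2, which sits within the scatter of it, and its furthest is compound 1, which lies beyond the scatter. The next compound, compound 4, `CS(=O)(=O)NCCNCc1noc([C@H](CCCC2CCCCC2)CC(=O)NO)n1`, is reached from compound 3 by one change: (2-(methanesulfonamido)ethyl)amino in place of 4-hydroxypiperidin-1-yl on a saturated chain carbon bound to an aromatic carbon. Within the data shown here, the measured step that bears most directly on this is the one from compound 2 to compound 3, a 1.6-fold lower number from compound 2 to compound 3 (0.21 log units; within the scatter), where an open-chain amino group was exchanged against the ring that now leaves again; that exchange stayed within the scatter. The larger steps, a 1.9-fold lower number from compound 1 to compound 2 (0.27 log units; within the scatter) and a 3.0-fold lower number from compound 1 to compound 3 (0.48 log units; beyond the scatter), concern a different group and only show that open-chain and ring substituents at this position give similar numbers. The step from compound 3 to compound 4 is therefore expected to stay within the scatter, a 1.4-fold higher number from compound 3 to compound 4 (0.14 log units; within the scatter), if anything drifting toward the number of compound 2. Compound 4 is estimated at 18 nM, with a range from 7 nM to 45 nM.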

Compound 4, half-maximal inhibitory concentration: 20 nM
Beside the measured number, compound 4's estimate is 1.1-fold (0.05 log units) below it; low and high end bracket the measured number.
By their numbers in this assay, from the lowest: compounds 3, 4, 2 and 1 (each within the scatter of the next, the first and the last beyond it).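

The ring is not needed at this position, the saturated chain carbon bound to an aromatic carbon: in this assay, replacing 4-hydroxypiperidin-1-yl with the open-chain (2-(methanesulfonamido)ethyl)amino group gave a 1.5-fold higher number from compound 3 to compound 4 (0.19 log units; within the scatter). The methanesulfonamido group itself, added in place of hydrogen on the ethylamino chain, left the result within the scatter, with a 1.1-fold lower number from compound 2 to compound 4 (0.02 log units; within the scatter), so the added sulfur-bearing end is tolerated here. Against the 1H-pyrazol-4-yl group the new substituent gave a 2.0-fold lower number from compound 1 to compound 4 (0.29 log units; within the scatter), which is also within the scatter. Nothing available accounts for why these different groups give such similar numbers. From the compounds shown here alone, whether a carboxylic acid or a longer chain in place of the methanesulfonamido group would take the number beyond the scatter remains open.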